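The source may hold more compounds than are shown below. What is called first, only, known or untested is meant among the compounds shown, and "the series" means these compounds.

Measured so far:
compound 1 `COc1cc(-c2cc(/C=C/C(=O)c3ccc(N)cc3)[nH]n2)cc(OC)c1OC` gives -45%
compound 2 `COc1ccc(C(=O)/C=C/c2cc(-c3cc(OC)c(OC)c(OC)c3)n[nH]2)cc1OC` gives -82%
compound 3 `COc1ccc(C(=O)/C=C/c2cc(-c3cc(OC)c(OC)c(OC)c3)n[nH]2)cc1` gives -69%

All three numbers come from a functional assay on SN12C cells (Homo sapiens) for cytotoxicity, read by sulforhodamine B assay, with a stated time of 48 h, tested at 10 uM; a higher number here means a weaker effect of the compound at the concentration tested, a lower number a stronger effect. Compound 1 has the highest number of the three and so the weakest effect at this concentration; how its core differs from that of compound 2 is given by 4-aminophenyl in place of 3,4-dimethoxyphenyl on a carbonyl carbon. Between compound 2 and compound 3 the change is hydrogen in place of methoxy on an aromatic carbon, and it brought a number 13 percentage points higher from compound 2 to compound 3 (beyond the scatter).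

The unmeasured compound 4 `COc1ccc(-c2cc(/C=C/C(=O)c3ccc(N)cc3)[nH]n2)cc1OC` relates to compound 1 through (hydrogen in place of methoxy on an aromatic carbon). For the measured compounds named here, this is the same kind of change as the one from compound 2 to compound 3, though not the same: in compound 1 the place is additionally meta to a methoxy group, which is not so in compound 2.

The expected step is a number 13 percentage points higher from compound 1 to compound 4 (beyond the scatter), resting on compound 1 standing at -45% and on the earlier step of a number 13 percentage points higher from compound 2 to compound 3 (beyond the scatter) pointing toward a weaker effect when a methoxy is removed. Compound 4 is therefore expected to give about -32%, within -55% to -8%.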

Compound 4, a percentage reported as activity, at one concentration (the size of the read-out at that concentration, not a potency): 14%
Compound 4: middle estimate off by 46 percentage points, on the low side, outside the stated range (above it).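

In this assay, hydrogen in place of methoxy on an aromatic carbon brought a number 59 percentage points higher from compound 1 to compound 4 (beyond the scatter), so the size of this step did not carry over from one core to the other: the same change on two cores in this assay, a number 13 percentage points higher (beyond the scatter) from compound 2 to compound 3 and a number 59 percentage points higher (beyond the scatter) from compound 1 to compound 4, 46 percentage points apart, beyond the scatter of two such steps The direction did hold, since both steps point toward a weaker effect, but two pairs are too few to call that a rule for the series. What these results do not show is why the sizes differ, since the two pairs differ in the rest of the molecule and also in the surroundings of the methoxy that leaves, and these compounds cannot separate those two things.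

The compounds shown leave open how a hydroxyl group or a fluorine atom in that same place would compare with methoxy and hydrogen. They also leave open whether an ethoxy group would behave like the methoxy on either core.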